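Thiophene Attachment Point in Hydroxyphenyl Pyridines on HeLa Cells

The compounds below may be only part of what the source reports. "The series", "measured", "known", "first", "only" and "open" are said of these compounds alone.

The measured compounds and their values:
Compound 1, `Oc1ccc(-c2cc(-c3ccccc3)cc(-c3cccs3)n2)cc1`: 1700 nM
Compound 2, `Oc1ccc(-c2cc(-c3ccccc3)cc(-c3ccsc3)n2)cc1`: 17300 nM
Compound 3, `Oc1cccc(-c2cc(-c3ccccc3)nc(-c3cccs3)c2)c1`: 15300 nM

All three were tested in a functional assay on HeLa cells (Homo sapiens) for cytotoxicity, read by ELISA, with a stated time of 2 days; on this read-out higher numbers stand for weaker inhibition and lower numbers for stronger inhibition. Compound 1 and compound 2 share a core and differ in one place: thiophen-3-yl in place of thiophen-2-yl on an aromatic carbon. This change produced a 10-fold higher number from compound 1 to compound 2 (1.01 log units; beyond the scatter), a step the scatter of repeat measurements does not cover.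

Compound 3 has the same atoms as compound 1 joined differently; the difference between the two cores is not broken down here. In this assay compound 3 gives 15300 nM, which sits close to the value of compound 2 and far from the value of compound 1.

Compound 4, `Oc1cccc(-c2cc(-c3ccccc3)nc(-c3ccsc3)c2)c1`, has not yet been measured. It relates to compound 3 by thiophen-3-yl in place of thiophen-2-yl on an aromatic carbon. Among the compounds with values here, this is the same kind of change as the one from compound 1 to compound 2, but not the same: around the place, compound 4 is meta to a 3-hydroxyphenyl group where compound 2 is meta to a 4-hydroxyphenyl group. Within the data shown here, with only one example of this change, the expected step for compound 4 is a 3.9-fold higher number from compound 3 to compound 4 (0.59 log units; beyond the scatter), resting on the earlier step of a 10-fold higher number from compound 1 to compound 2 (1.01 log units; beyond the scatter) and tempered by the uncertainty that the change sits in a different core. Compound 4 is therefore expected to give roughly 60000 nM, between 20000 nM and 200000 nM, with a real chance that the assay returns only a limit.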

Compound 4, half-maximal inhibitory concentration: 14900 nM
Estimate against measurement, compound 4: 4.0-fold (0.60 log units) above, outside the stated range (below it).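

On the core of compound 3, thiophen-3-yl in place of thiophen-2-yl gave a 1.0-fold lower number from compound 3 to compound 4 (0.01 log units; within the scatter) in this assay, so the attachment point of the thiophene, which separated compound 1 from compound 2, does not separate this pair. The same change therefore cannot be carried from one core to the other in this series with its size intact, and the gap between the two steps is a real one: the same change on two cores in this assay, a 10-fold higher number (1.01 log units; beyond the scatter) from compound 1 to compound 2 and a 1.0-fold lower number (0.01 log units; within the scatter) from compound 3 to compound 4, 10-fold (1.02 log units) apart, beyond the scatter of two such steps

This does not show what sets the two cores apart, since they differ in how their rings are joined and that difference is not broken down into single changes, and with one pair on each core it gives no rule for any further core.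

Every compound shown carries a hydroxyphenyl group, so it remains open how the thiophene attachment point would read on either core with an amine or a carboxylic acid in place of the hydroxyl. Also open, from the compounds shown here alone, is whether the contrast between the two cores would survive if a longer chain took the place of the phenyl group that all four compounds share.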